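A few compounds are considered here, and "the series" means these few. Any claim that something is new, unique, unknown or untested is made for them only; others in the source may bear on it.

For the measured compounds named here, in a functional assay on SK-MEL-2 cells (Homo sapiens) for inhibition, read by sulforhodamine B assay, with a stated time of 48 h (a lower number here means a stronger inhibitor of growth, a higher number a weaker inhibitor of growth), compound 2 `COc1ccc(C(=O)/C=C/c2cc(-c3cc(OC)c(OC)c(OC)c3)n[nH]2)cc1OC` gives 3510 nM, the lowest of the three numbers measured so far. Compound 1 `COc1cc(-c2cc(/C=C/C(=O)c3ccc(N)cc3)[nH]n2)cc(OC)c1OC` gives 7530 nM, and compound 3 `COc1ccc(C(=O)/C=C/c2cc(-c3cc(OC)c(OC)c(OC)c3)n[nH]2)cc1` gives 19600 nM. Compound 4 `COc1cc(C(=O)/C=C/c2cc(-c3cc(OC)c(OC)c(OC)c3)n[nH]2)cc(OC)c1OC` is obtained from compound 2 by methoxy in place of hydrogen on an aromatic carbon. Going by the values given here, two measured steps bear on this change. Taking one methoxy group away gave a 5.6-fold higher number from compound 2 to compound 3 (0.75 log units; beyond the scatter), and exchanging the aminophenyl for the dimethoxyphenyl gave a 2.1-fold lower number from compound 1 to compound 2 (0.33 log units; beyond the scatter). Both point the same way among these compounds: more methoxy groups on this ring have gone with a lower number. The added methoxy is therefore expected to lower the number once more, by a modest step of a 1.6-fold lower number from compound 2 to compound 4 (0.20 log units; within the scatter). Compound 4 is estimated at 2200 nM, with a range from 900 nM to 5500 nM.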

Compound 4, concentration for total growth inhibition: 4040 nM
Compound 4: middle estimate off by 1.8-fold (0.26 log units), on the low side; low and high end bracket the measured number.
By their numbers in this assay, from the lowest: compounds 2, 4 and 1 (each within the scatter of the next, the first and the last beyond it); then compound 3.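

In this assay, the third methoxy gives a 1.2-fold higher number from compound 2 to compound 4 (0.06 log units; within the scatter), so on this ring the step that mattered on removal, a 5.6-fold higher number from compound 2 to compound 3 (0.75 log units; beyond the scatter), does not continue once two methoxy groups are present. This aromatic carbon accepts a methoxy group without a change that can be told from scatter, so the link between more methoxy groups and a lower number does not hold for compound 4. Nothing given here explains why the trend stops.
Going by these compounds, whether a hydroxyl group or a longer chain such as ethoxy at this place would shift the number remains open.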